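The source may hold more compounds than are shown below. What is called first, only, known or untested is meant among the compounds shown, and "the series" means these compounds.

In a functional assay on MGC-803 cells (Homo sapiens) for inhibition, read by MTT assay, with a stated time of 72 h (on this read-out higher numbers stand for weaker inhibition and lower numbers for stronger inhibition), compound 1 `O=C(CSc1nc(Nc2ccccc2)c2ccccc2n1)Nc1ccc(Cl)c(Cl)c1` gives 37900 nM. Compound 2 `O=C(CSc1nc(Nc2ccccc2)c2ccccc2n1)Nc1ccc(F)c(Cl)c1` gives 20900 nM in this assay, and the change chloro in place of fluoro on an aromatic carbon made a 1.8-fold higher number from compound 2 to compound 1 (0.26 log units; within the scatter). Compound 3 `C=CC(=O)Nc1cccc(NC(=O)CSc2nc(Nc3cccc(F)c3)c3ccccc3n2)c1` gives 6250 nM in this assay, the lowest of the three numbers; its core differs from that of compound 2, but the difference between the two cores is not broken down here. Compound 4 `C=CC(=O)Nc1cccc(NC(=O)CSc2nc(Nc3cccc(Cl)c3)c3ccccc3n2)c1` has not been measured and differs from compound 3 by chloro in place of fluoro on an aromatic carbon. This is the same kind of change as between compound 2 and compound 1, though not the same: there the site was ortho to a chloro group and para to a large group, here it is meta to a large group. Because a 1.8-fold higher number from compound 2 to compound 1 (0.26 log units; within the scatter) lay within the scatter, compound 4 is expected to show a 1.3-fold higher number from compound 3 to compound 4 (0.11 log units; within the scatter), also within the scatter. Compound 4 is therefore estimated at 8000 nM, between 3500 nM and 18000 nM.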

Compound 4, half-maximal inhibitory concentration: 7830 nM
Compound 4: middle estimate off by 1.0-fold (0.01 log units), on the high side, and the stated range covers the measured number.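

In this assay, chloro in place of fluoro on an aromatic carbon gave a 1.3-fold higher number from compound 3 to compound 4 (0.10 log units; within the scatter), so on this second core the change again cannot be told from the scatter. Set beside the earlier case, the two steps agree: the same change on two cores in this assay, a 1.8-fold higher number (0.26 log units; within the scatter) from compound 2 to compound 1 and a 1.3-fold higher number (0.10 log units; within the scatter) from compound 3 to compound 4, 1.4-fold (0.16 log units) apart, within the scatter of two such steps. This shows that the change stayed small on both cores, but two pairs with steps inside the scatter, at sites that are not the same, show neither a real effect of the change nor that it would stay small on any other core.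

The compounds shown leave open whether a different group at this place, such as a methoxy group, an amine or a nitrile, would give a step beyond the scatter. Also open, as far as these compounds go, is what a propanamide in place of the acrylamide of compound 3 and compound 4 would give.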